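The source may report more compounds than this note shows. Statements on the series, on what has been measured and on what is new or still open speak of the compounds shown alone.

Measured compounds:
- compound 1 `CNC(=O)c1cncc(NS(=O)(=O)c2cc(Cl)ccc2OC)c1`: 109 nM
- compound 2 `COc1ccc(Cl)cc1S(=O)(=O)Nc1cncc(C(N)=O)c1`: 16 nM
- compound 3 `COc1ccc(Br)cc1S(=O)(=O)Nc1cncc(C(N)=O)c1`: 14 nM

In an assay on isolated protein for inhibition of alkaline phosphatase, tissue-nonspecific isozyme (Homo sapiens) (a higher number here means a weaker inhibitor, a lower number a stronger inhibitor), compound 2 gives 16 nM. Among the three numbers it sits close to compound 3, the step from compound 2 to compound 3 being a 1.1-fold lower number from compound 2 to compound 3 (0.06 log units; within the scatter), while it stands well apart from compound 1, since the step from compound 1 to compound 2 is a 6.8-fold lower number from compound 1 to compound 2 (0.83 log units; beyond the scatter).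

Compound 4 `CCNC(=O)c1cncc(NS(=O)(=O)c2cc(Cl)ccc2OC)c1` differs from compound 2 by ethyl in place of hydrogen on an amide-type nitrogen. Going by the values given here, the one measured step that bears on this place is the one from compound 1 to compound 2, a 6.8-fold lower number from compound 1 to compound 2 (0.83 log units; beyond the scatter), where removing a methyl from the same amide-type nitrogen lowered the number beyond the scatter. The step from compound 2 to compound 3 concerns a different place and lies within the scatter, so it says nothing here. Putting an ethyl onto that nitrogen is therefore expected to move the number in the opposite direction to that step, by a similar or somewhat larger amount. Compound 4 is thus estimated at 150 nM in this assay, with a range from 50 nM to 500 nM. The expected step from compound 2 to compound 4 is a 9.4-fold higher number from compound 2 to compound 4 (0.97 log units; beyond the scatter).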

Compound 4, half-maximal inhibitory concentration: 193 nM
The estimate for compound 4 lay 1.3-fold (0.11 log units) below the measured number; measured number inside the range.
By their numbers in this assay, from the lowest: compounds 3 and 2 (each within the scatter of the next); then compounds 1 and 4 (each within the scatter of the next).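

In this assay, the step of a 12-fold higher number from compound 2 to compound 4 (1.08 log units; beyond the scatter) shows that the rise seen with methyl on the amide-type nitrogen is not peculiar to that one group, as ethyl there also gives a large rise over the amide hydrogen. The step of a 1.8-fold higher number from compound 1 to compound 4 (0.25 log units; within the scatter) stays within the scatter, so the added carbon makes no difference that can be told apart and the two substituted compounds sit level. Across these compounds, what separates the numbers at this position is whether the nitrogen keeps its hydrogen or carries a methyl or ethyl, not which of those two chains it carries. Nothing shown here accounts for this result.

On these data alone, it remains open whether a longer chain, or a chain ending in an amine or a carboxylic acid, would stay at the level of compound 1 and compound 4 on this nitrogen. As far as these compounds go, it is also open whether ethyl on this nitrogen would give a similar step with the bromo group of compound 3 in place of chloro.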